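This account rests on a few compounds, and the source may have more. Where it says the series, first, only, none or still open, it means among the compounds named here.

Of the compounds shown here, three of one shared core have been measured in a functional assay on NCI-H23 cells (Homo sapiens) for cytotoxicity, read by sulforhodamine B assay, with a stated time of 48 h, tested at 100 uM; on this read-out higher numbers stand for a weaker effect at the one concentration tested and lower numbers for a stronger effect. Compound 1 `COc1ccc(-c2cc(/C=C/C(=O)c3ccc(N)cc3)[nH]n2)cc1` gives -62%. Compound 2 `COc1cc(-c2cc(/C=C/C(=O)c3ccc(N)cc3)[nH]n2)cc(OC)c1OC` gives -55%, which is the second highest of the three numbers, with compound 1 nearest and compound 3 furthest. Compound 3 `COc1cc(-c2cc(/C=C/C(=O)c3ccc(F)c(F)c3)[nH]n2)cc(OC)c1OC` gives -27%. Among the compounds with values here, the only measured step that differs in a single place is a number 28 percentage points higher from compound 2 to compound 3 (beyond the scatter), a change of the aryl group on the carbonyl carbon.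

Compound 4 `COc1ccc(-c2cc(/C=C/C(=O)c3ccc(N)cc3)[nH]n2)cc1OC` differs from compound 2 by a change on the other aromatic ring: hydrogen in place of methoxy on an aromatic carbon. The measured step from compound 2 to compound 3 sits elsewhere in the molecule and so does not speak directly to this change. What can be said is that compound 1, carrying a single methoxy group on that ring, and compound 2, carrying three, give values that lie within the usual scatter of each other. Compound 4, with two methoxy groups, stands between them in that respect, so no step beyond the scatter is expected in this assay. Compound 4 is therefore estimated at -58%, within a range from -78% to -38%, meaning an expected step of a number 3 percentage points lower from compound 2 to compound 4 (within the scatter).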

Compound 4, a percentage reported as activity, at one concentration (the size of the read-out at that concentration, not a potency): -51%
Compound 4: middle estimate off by 7 percentage points, on the low side; low and high end bracket the measured number.
By their numbers in this assay, from the lowest: compounds 1, 2 and 4 (each within the scatter of the next, the first and the last beyond it); then compound 3.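

In this assay, hydrogen in place of the methoxy group that sits ortho to a methoxy group and meta to a large group gives a number 4 percentage points higher from compound 2 to compound 4 (within the scatter), so this methoxy group can be lost from the trimethoxy ring without a difference that this read-out can resolve. Within the data shown here, the reverse kind of change, starting from the ring of compound 1, tells a different story: methoxy in place of hydrogen on an aromatic carbon gives a number 11 percentage points higher from compound 1 to compound 4 (beyond the scatter), a modest step toward a weaker effect, and the first step on this ring to lie beyond the scatter, since the only step available before concerned the aryl group on the carbonyl carbon. Nothing among the data shown offers a reason for either step.

On these data alone, whether another group on this aromatic carbon, such as a hydroxyl, a fluorine, an amine or a longer ether chain, would stay within the scatter of compound 2 remains open. Also open, as far as these compounds go, is whether the same methoxy change would give a similar step with the 3,4-difluorophenyl group of compound 3 on the carbonyl carbon in place of the 4-aminophenyl group.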